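The compounds below may be only part of what the source reports. "The series", "measured", "known", "first", "only" and "open" are said of these compounds alone.

In a functional assay on PC-3 cells (Homo sapiens) for cytotoxicity, read by MTT assay, with a stated time of 72 h (a higher number here means a weaker inhibitor, a lower number a stronger inhibitor), three compounds with a shared core have been measured. Compound 1 `CNC(=O)c1cc(Oc2ccc(C(=O)/C=C/c3cccc(Br)c3)cc2)ccn1` gives 3400 nM, compound 2 `CNC(=O)c1cc(Oc2ccc(C(=O)/C=C/c3ccc(F)cc3Cl)cc2)ccn1` gives 4760 nM and compound 3 `CNC(=O)c1cc(Oc2ccc(C(=O)/C=C/c3ccc(C#N)cc3)cc2)ccn1` gives 3870 nM. These numbers are too close to rank, so compound 3 stands level with the other two.

The next compound keeps the same core. Compound 4 `CNC(=O)c1cc(Oc2ccc(C(=O)/C=C/c3ccc(F)cc3)cc2)ccn1` differs from compound 3 by a single small substitution: fluoro in place of cyano on an aromatic carbon. Put simply, the 4-cyanophenyl group of compound 3 becomes a 4-fluorophenyl group in compound 4.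

Within the data shown here, no measurement yet covers this exact swap, but three measured steps change the same substituted phenyl group and so offer the closest guide. They are a 1.4-fold higher number from compound 1 to compound 2 (0.15 log units; within the scatter), a 1.1-fold higher number from compound 1 to compound 3 (0.06 log units; within the scatter) and a 1.2-fold lower number from compound 2 to compound 3 (0.09 log units; within the scatter). None of the three leaves the scatter, and together they point in no consistent direction. Three compounds are a small sample, but they give no reason to expect a real shift in this assay for compound 4, in either direction.

The estimated step is a 1.0-fold lower number from compound 3 to compound 4 (0.01 log units; within the scatter). Compound 4 is expected to give about 3800 nM, with an estimated range of 2000 nM to 7200 nM.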

Compound 4, half-maximal inhibitory concentration: 6140 nM
Estimate against measurement, compound 4: 1.6-fold (0.21 log units) below; measured number inside the range.
By their numbers in this assay, from the lowest: compounds 1, 3, 2 and 4 (each within the scatter of the next).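

In this assay, putting fluoro in place of cyano on the same aromatic carbon gives a 1.6-fold higher number from compound 3 to compound 4 (0.20 log units; within the scatter) and so this position accepts the loss of the nitrile, with its one hydrogen-bond acceptor, without a shift that stands clear of the usual variation. The two other new steps read the same way: hydrogen in place of chloro gives a 1.3-fold higher number from compound 2 to compound 4 (0.11 log units; within the scatter) and the 4-fluorophenyl group in place of 3-bromophenyl gives a 1.8-fold higher number from compound 1 to compound 4 (0.26 log units; within the scatter) and so the four compounds stay level on every step that involves compound 4. No outside measurement bears on this result.

On these data alone, the aromatic ring here carries only halogens or a nitrile, so it stays open whether an amine, a carboxylic acid or a methoxy group on the same aromatic carbon would give a step beyond the scatter. As far as these compounds go, the rest of the shared core is identical in all four compounds, so what a change there, such as a longer chain on the amide nitrogen, would do to the number also stays open.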